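Thiazole hydrazone series: fluoro for chloro at compound 4

The source may report more compounds than this note shows. Statements on the series, on what has been measured and on what is new or still open speak of the compounds shown alone.

Three members of the series have been run through a functional assay, read by spectrophotometry, with a stated time of 15 min, tested at 20 ug/mL; on this read-out higher numbers stand for a stronger effect at the one concentration tested and lower numbers for a weaker effect. Compound 1 `COC(=O)c1cc(-c2csc(N/N=C/c3cccs3)n2)ccc1OCc1ccccc1` gives 79.6% in this assay. Compound 2 `Clc1ccc(-c2csc(N/N=C/c3cccs3)n2)cc1` gives 82.8% in this assay. Compound 3 `Cc1ccc(-c2csc(N/N=C/c3ccc(Cl)cc3Cl)n2)cc1` gives 76.2% in this assay. Compound 2 stands at the top of these three numbers, but its gaps to compound 1 and to compound 3 both lie within the scatter, so the three read as one cluster rather than an order.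

The next compound to be measured is compound 4 `Fc1ccc(-c2csc(N/N=C/c3cccs3)n2)cc1`. Relative to compound 2 it carries one change: fluoro in place of chloro on an aromatic carbon. Within the data shown here, no pair of measured compounds differs in only one place, so no measured step can be borrowed for this change. Given that all three measured numbers sit in one band, the expectation is that the step from chloro to fluoro produces no movement beyond the scatter in this assay, or at most a small downward one.

Compound 4 is therefore estimated at 78% in this assay, with a range from 65% to 88%. This estimate means a step of a number 4.8 percentage points lower from compound 2 to compound 4 (within the scatter), expected to stay within the scatter.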

Compound 4, a percentage reported as inhibition, at one concentration (the size of the read-out at that concentration, not a potency): 84.2%
Estimate against measurement, compound 4: 6.2 percentage points below, within the range that was stated.
By their numbers in this assay, from the lowest: compounds 3, 1, 2 and 4 (each within the scatter of the next).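

Fluoro in place of chloro on an aromatic carbon, para to a large group, is the first change in the series that can be read in one place, and in this assay it gives a number 1.4 percentage points higher from compound 2 to compound 4 (within the scatter). Among these compounds, earlier comparisons each differed in more than one place, so they could not isolate this position; here, the two halogens cannot be told apart, with the rest of compound 2 unchanged. Nothing on hand bears on what lies behind this result.

Going by these compounds, the reading covers only these two halogens at this position, so an amine, a carboxylic acid or a longer chain there remains open. Also open, on these data alone, is whether the same exchange would read alike with the other parts of the molecule changed, as they are in compound 1 and compound 3.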